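The compounds below may be only part of what the source reports. "The series", "measured", "known", "first", "only" and "open" are said of these compounds alone.

Of the compounds shown here, three that share one core have been read in a physicochemical assay for solubility, measured as kinetic solubility; on this read-out higher numbers stand for higher solubility and lower numbers for lower solubility: compound 1 `CNC(=O)c1cc(C(=O)N[C@H]2CC[C@H](O)CC2)c([C@@H](C)c2cccc(Cl)c2)o1`, compound 2 `CNC(=O)c1cc(C(=O)N[C@H]2CC[C@H](O)CC2)c([C@@H](C)c2cccc(F)c2)o1` and compound 3 `CNC(=O)c1cc(C(=O)N[C@H]2CC[C@H](O)CC2)c([C@@H](C)c2ccccc2Cl)o1`. Compound 1 gives only a limit, >= 179 ug/mL. Compound 2 also gives only a limit, >= 63 ug/mL. Compound 3, the starting point here, likewise gives only a limit, >= 242 ug/mL, so it has no exact number to stand on.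

Compound 4 `CNC(=O)c1cc(C(=O)N[C@H]2CC[C@H](O)CC2)c([C@@H](C)c2ccc(Cl)cc2)o1` has the same atoms as compound 3, joined differently: 4-chlorophenyl in place of 2-chlorophenyl on a saturated chain carbon bound to an aromatic carbon and a saturated chain carbon. It carries 4-chlorophenyl in place of 2-chlorophenyl on a saturated chain carbon bound to an aromatic carbon and a saturated chain carbon.

The closest measured change also exchanges one chlorophenyl for another, 2-chlorophenyl in place of 3-chlorophenyl, and it is a step that the two limits leave unreadable from compound 1 to compound 3. The two remaining changes are a step that the two limits leave unreadable from compound 1 to compound 2 and a step that the two limits leave unreadable from compound 2 to compound 3. None of the three offers a size or a direction to carry over, so no step beyond the usual scatter can be argued for, and compound 4 may well return a limit too. The expected change is therefore an at least 1.2-fold lower number from compound 3 to compound 4 (0.08 log units; that floor lies within the scatter), with no direction foreseen. In this assay, compound 4 is estimated at 200 ug/mL, within an expected range of 80 ug/mL to 450 ug/mL.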

Compound 4, solubility: >= 118 ug/mL
Compound 4: a limit, no number (the forecaster's own chance of this, stated with the estimate: 75%); the middle value is on the limit's open side.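

In this assay compound 4 gives only a limit, like compound 1, compound 2 and compound 3, so none of its steps to those three compounds can be read. The compounds shown leave open where the true values of all four lie, and whether the 2-chlorophenyl, 3-chlorophenyl and 4-chlorophenyl compounds differ at all in this assay.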